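Thioether chain: 3-fluoropropyl to 2-hydroxyethyl

The source may hold more compounds than are shown below. What is called first, only, known or untested is meant among the compounds shown, and "the series" means these compounds.

Measured in a functional assay on L5178Y cells (Mus musculus), with a stated time of 48 h; on this read-out lower numbers stand for stronger inhibition and higher numbers for weaker inhibition:
- compound 1 `CCCSC[C@H]1OC(n2cnc3c(N)ncnc32)[C@H](O)[C@@H]1O`: 500000 nM
- compound 2 `Nc1ncnc2c1ncn2C1O[C@H](CSCCCF)[C@@H](O)[C@H]1O`: 600000 nM

Within the data shown here, compound 2 stands level with compound 1, the only measured step being a 1.2-fold higher number from compound 1 to compound 2 (0.08 log units; within the scatter). Compound 3 `Nc1ncnc2c1ncn2C1O[C@H](CSCCO)[C@@H](O)[C@H]1O` follows from compound 2 by hydroxy in place of fluoromethyl on a saturated chain carbon, two bonds along the chain from a sulfur, with hydroxy in place of fluoromethyl on a saturated chain carbon, two bonds along the chain from a sulfur. Among the measured compounds shown here, the one measured step is a different change on the same chain, so it offers limited guidance, and no shift beyond the scatter is expected in this assay. The expected step is no change at the digits printed from compound 2 to compound 3 (within the scatter). The estimate for compound 3 is 600000 nM, with an expected range of 250000 nM to 1500000 nM.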

Compound 3, half-maximal inhibitory concentration: 500000 nM
For compound 3 the middle estimate is 1.2-fold (0.08 log units) above the measured one; the measured number falls inside the stated range.
By their numbers in this assay, from the lowest: compounds 1, 3 and 2 (each within the scatter of the next).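

In this assay, hydroxy in place of fluoromethyl on a saturated chain carbon, two bonds along the chain from a sulfur, gives a 1.2-fold lower number from compound 2 to compound 3 (0.08 log units; within the scatter) and hydroxy in place of methyl there gives no change at the digits printed from compound 1 to compound 3 (within the scatter) with both steps inside the scatter. Entry of a hydrogen-bond donor and acceptor at this place therefore produces no step beyond the scatter from either neighbour. No supporting data explain this result.

On these data alone, whether an amine, a carboxylic acid or a longer chain here would produce a step beyond the scatter remains open.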